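Swapping a Trifluoromethoxy for a Methyl Group

The source may hold more compounds than are shown below. What is called first, only, known or untested is meant among the compounds shown, and "the series" means these compounds.

Compound 1, `Cc1ccc2c(=O)[nH]c(-c3cccc(OC(F)(F)F)c3)nc2c1`, was tested in a functional assay on HeLa cells (Homo sapiens) for cytotoxicity, read by MTT assay, with a stated time of 2 days; a higher number here means a weaker inhibitor, a lower number a stronger inhibitor. In this assay compound 1 gives only a limit of > 50000 nM, not a measured number, so its true strength is known only to lie beyond the range the assay can report; this is the case noted as the limit of > 50000 nM in this assay, at which 1 of the 3 values shown sits. Two further compounds share the same core. Compound 2, `CCN(CC)c1ccc2nc(-c3cccc4ccccc34)[nH]c(=O)c2c1`, gives 4 nM in this assay. Compound 3, `Cc1ccc2c(=O)[nH]c(-c3ccccc3F)nc2c1`, gives 830 nM, a measured number.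

The unmeasured compound 4, `Cc1cccc(-c2nc3cc(C)ccc3c(=O)[nH]2)c1`, differs from compound 1 in one place: methyl in place of trifluoromethoxy on an aromatic carbon. The change sits on an aromatic carbon of a six-membered aromatic ring of carbon only, meta to a large group.

Going by the values given here, no step between two measured compounds matches this change, so the size of the step is open. Compound 3 shows that a small substituent on this ring is compatible with a measured number, but compound 1 shows that a larger one is not. A move from the limit toward a measured value is expected, though it may remain modest.

Compound 4 is expected to give 8000 nM in this assay, within 800 nM to 50000 nM, the step of an at least 6.2-fold lower number from compound 1 to compound 4 (0.79 log units; beyond the scatter) being an estimate only.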

Compound 4, half-maximal inhibitory concentration: 11200 nM
Estimate against measurement, compound 4: 1.4-fold (0.15 log units) below; the measured number falls inside the stated range.
By their numbers in this assay, from the lowest: compound 2; then compound 3; then compound 4. At a limit, above all of these: compound 1.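

The swap of trifluoromethoxy for methyl on this aromatic carbon gives, in this assay, an at least 4.4-fold lower number from compound 1 to compound 4 (0.64 log units; beyond the scatter), so what sits at this position clearly matters for the read-out. Going by these compounds alone, until now no step between two measured compounds could show this, and compound 4 now gives this position a measured number against which other groups at the same carbon can be compared. The step is a minimum only, since compound 1 stands at a limit of the assay, and the real gap may be larger: the limit of > 50000 nM in this assay, at which 1 of the 4 values shown sits.

One swap cannot tell whether the oxygen, the fluorines or the drop from 5 heavy atoms to 1 accounts for the lower number; a methoxy group, a trifluoromethyl group or a plain hydrogen on this carbon would help to separate these. Also open, from the compounds shown here alone, is how far this position contributes to the much lower number of compound 2, at 4 nM, as compound 2 differs from compound 4 in more than one place.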